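The source may report more compounds than this note shows. Statements on the series, on what has been measured and on what is new or still open speak of the compounds shown alone.

Of the compounds shown here, three sharing one core have been tested so far in an ADME assay on HEK-293T cells (Homo sapiens) for cytotoxicity, read by luminescence, with a stated time of 24 h (on this read-out higher numbers stand for lower toxicity in this test and lower numbers for higher toxicity in this test), across this small set. Compound 1 (`COc1ccc(Cn2c(C(=O)N3CCC(C(=O)NCc4cccc(Br)c4)CC3)cc3sccc32)cc1`) reads > 100000 nM in this test, which is a limit of the assay and not a number. Compound 2 (`COc1ccc(Cn2c(C(=O)N3CCC(C(=O)NCC4CC4)CC3)cc3sccc32)cc1`) reads 24600 nM as a real number. Compound 3 (`CCCNC(=O)C1CCN(C(=O)c2cc3sc(C(=O)c4ccccc4)cc3n2Cc2ccc(OC)cc2)CC1`) reads > 100000 nM and this too is only a limit. Compound 3 thus stands at the limit of > 100000 nM in this assay, at which 2 of the 3 values shown sit, and no exact figure is known for it.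

Compound 4 (`CCCNC(=O)C1CCN(C(=O)c2cc3sc(CNC(C)c4ccccc4)cc3n2Cc2ccc(OC)cc2)CC1`) has not yet been measured. It differs from compound 3 at one place (((1-phenylethyl)amino)methyl in place of benzoyl on an aromatic carbon), with ((1-phenylethyl)amino)methyl in place of benzoyl on an aromatic carbon. Within the data shown here, no measured step touches that place. The nearest guide is an at least 4.0-fold lower number from compound 1 to compound 2 (0.60 log units; beyond the scatter) and it swaps 3-bromophenyl for cyclopropyl elsewhere on the molecule, yet it shows that one change can bring a number down from the limit. Starting from a limit, any visible change from compound 3 would be a lower number. Among the measured compounds shown here, compound 2 at 24600 nM holds the only real number available. A modest drop toward that number is expected for compound 4, though the limit may be reported again. The estimated change is an at least 2.5-fold lower number from compound 3 to compound 4 (0.39 log units; beyond the scatter) in the direction of lower numbers. For compound 4 the expected value is 40000 nM with an estimated range from 12000 nM to 100000 nM at its upper end.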

Compound 4, half-maximal cytotoxic concentration: 33900 nM
Beside the measured number, compound 4's estimate is 1.2-fold (0.07 log units) above it; the range from low to high includes it.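

In this assay, the aromatic carbon next to the ring sulfur is now shown to matter: placing ((1-phenylethyl)amino)methyl there in place of benzoyl gives an at least 2.9-fold lower number from compound 3 to compound 4 (0.46 log units; beyond the scatter), which means higher toxicity in this test. Among these compounds, until now, the only readable step lay on the chain at the amide-type nitrogen, so this is the first sign that a change at this other position can also bring the number down from the limit. Going by these compounds, compound 3 is a limit and not a number, so the full size of this step stays unknown: the limit of > 100000 nM in this assay, at which 2 of the 4 values shown sit.

The two groups both carry a six-membered aromatic ring, but the entering group has a nitrogen and a hydrogen-bond donor where benzoyl has a carbonyl, and the compounds shown cannot tell which part of the swap accounts for the lower number. On these data alone, a plain aminomethyl group, a benzylaminomethyl group without the branching methyl, or a carboxylic acid at this position would help separate these parts, and the effect of such groups on this read-out remains open.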